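Replacing a phenoxy group with a hydroxypyrrolidine amide

A few compounds are considered here, and "the series" means these few. Any claim that something is new, unique, unknown or untested is made for them only; others in the source may bear on it.

Measured so far:
compound 1, `NCc1cc(Oc2cccc(Oc3ccccc3)c2)nc(C(F)(F)F)c1`: "not determined" (no result reported)
compound 2, `NCc1cc(O[C@H]2CCCN(C(=O)Nc3ccccc3)C2)nc(C(F)(F)F)c1`: 30000 nM

Two compounds sharing the same core have been examined in an ADME assay on the whole organism (lung, Mus musculus) for pharmacokinetics, read by LC-MS, at a dose of 30 mg/kg by the oral route; on this read-out higher numbers stand for higher exposure at the dose given and lower numbers for lower exposure. For compound 1, `NCc1cc(Oc2cccc(Oc3ccccc3)c2)nc(C(F)(F)F)c1`, no number was obtained in this assay, so it provides no fixed point on this read-out. Within the data shown here, compound 2, `NCc1cc(O[C@H]2CCCN(C(=O)Nc3ccccc3)C2)nc(C(F)(F)F)c1`, which carries a different side chain on the shared core, gives 30000 nM in this assay, and this is the only measured value available.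

The step from compound 1 to compound 3, `NCc1cc(Oc2cccc(C(=O)N3CC[C@@H](O)C3)c2)nc(C(F)(F)F)c1`, changes one group on the outer aromatic ring: (3-hydroxypyrrolidin-1-yl)carbonyl in place of phenoxy on an aromatic carbon. Since compound 1 has no value in this assay, no size or direction of step can be stated for it; the expectation for compound 3 rests on what compound 2 shows, namely 30000 nM, and on the fact that compound 3 also carries a ring bearing a hydrogen-bond donor and acceptors in place of a plain phenoxy group.

Compound 3 is expected to reach about 15000 nM in this assay, with a plausible range from 3000 nM to 60000 nM.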

Compound 3, maximal plasma concentration: 9130 nM
Beside the measured number, compound 3's estimate is 1.6-fold (0.22 log units) above it; the measured number falls inside the stated range.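

No step can be read from compound 1 to compound 3 in this assay, as compound 1 offers no number to set against compound 3. As far as these compounds go, what replacing phenoxy with (3-hydroxypyrrolidin-1-yl)carbonyl does to exposure therefore stays open. No supporting data bear on this result.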